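The source may report more compounds than this note shows. Statements on the series, on what has been measured and on what is new or still open speak of the compounds shown alone.

Compounds measured so far:
- Compound 1, `COc1c2ccccc2nn1C(C)C`: 704 nM
- Compound 2, `CCCCn1nc2ccccc2c1OC`: 910 nM
- Compound 3, `CCCCCn1nc2ccccc2c1OC`: 3880 nM

All three share one core and differ only in the chain on the aromatic nitrogen, and all were tested in an assay on isolated protein (urine) for inhibition of Myeloperoxidase (Homo sapiens), read by spectrophotometry; on this read-out lower numbers stand for stronger inhibition and higher numbers for weaker inhibition. Compound 3 stands at the highest number of the three: the step of a 5.5-fold higher number from compound 1 to compound 3 (0.74 log units; beyond the scatter) and the step of a 4.3-fold higher number from compound 2 to compound 3 (0.63 log units; beyond the scatter) both lie beyond the scatter, while the step of a 1.3-fold higher number from compound 1 to compound 2 (0.11 log units; within the scatter) does not.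

Compound 4, `CCCCCCCCn1nc2ccccc2c1OC`, carries the change (propyl in place of hydrogen on a saturated chain carbon, five bonds along the chain from an aromatic nitrogen), so the pentyl of compound 3 grows into an octyl chain. Among the compounds with values here, the steps that bear on this are the two that lengthen the chain, a 5.5-fold higher number from compound 1 to compound 3 (0.74 log units; beyond the scatter) and a 4.3-fold higher number from compound 2 to compound 3 (0.63 log units; beyond the scatter): both raised the number by a modest amount. Extending the chain further is therefore expected to raise the number again, most likely by a modest to clear amount, giving an estimated step of a 3.1-fold higher number from compound 3 to compound 4 (0.49 log units; beyond the scatter). Compound 4 is expected at about 12000 nM, with a range from 4000 nM to 40000 nM.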

Compound 4, half-maximal inhibitory concentration: > 10000 nM
Compound 4: only a limit was reported (the forecaster's own chance of this, stated with the estimate: 20%); the middle value is on the limit's open side.
By their numbers in this assay, from the lowest: compounds 1 and 2 (each within the scatter of the next); then compound 3. At a limit, above all of these: compound 4.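

Lengthening the chain on the aromatic nitrogen from pentyl to octyl gives an at least 2.5-fold higher number from compound 3 to compound 4 (0.41 log units; beyond the scatter), and going from butyl to octyl gives an at least 10-fold higher number from compound 2 to compound 4 (1.04 log units; beyond the scatter). So the climb in the number seen from compound 2 to compound 3 continues out to the octyl chain and does not turn back, while compound 1, with its isopropyl group, stays within the scatter of compound 2 and shows no such climb. Compound 4 gives > 10000 nM, which is a limit of the assay and not a number: the limit of > 10000 nM in this assay, at which 1 of the 4 values shown sits.

From the compounds shown here alone, the true size of the step to compound 4 therefore stays open. Also open, going by these compounds, are whether shorter chains such as methyl or ethyl give lower numbers, and whether a chain carrying an amine or a carboxylic acid would bring the number back down.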